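The compounds below may be only part of what the source reports. "The series", "measured", "known", "first", "only" and "open" are said of these compounds alone.

Of the compounds shown here, three have been measured in an assay on isolated protein for inhibition of alpha-ketoglutarate-dependent dioxygenase alkB homolog 3 (Homo sapiens), read by polymerase chain reaction, with a stated time of 1 h; a higher number here means a weaker inhibitor, a lower number a stronger inhibitor. Compound 1 `COc1ccc(Cc2c(C)[nH]n(-c3nc4ccccc4[nH]3)c2=O)cc1` gives 630 nM. Compound 2 `Oc1c(-c2ccccc2)c(-c2ccccc2)nn1-c1nc2cc(Cl)ccc2[nH]1` gives 2000 nM. Compound 3 `Cc1[nH]n(-c2nc3ccccc3[nH]2)c(=O)c1CC(=O)O` gives 15000 nM, the highest of the three numbers, so it is the weakest inhibitor here; its nearest neighbour is compound 2, and compound 1 lies furthest from it. Compound 4 `Cc1[nH]n(-c2nc3ccccc3[nH]2)c(=O)c1Cc1cccc(Cl)c1` differs from compound 3 in one place: 3-chlorophenyl in place of carboxy on a saturated chain carbon bound to an aromatic carbon. Going by the values given here, one measured step bears on this change. Putting carboxy in place of 4-methoxyphenyl on the same saturated chain carbon gave a 24-fold higher number from compound 1 to compound 3 (1.38 log units; beyond the scatter). The change to compound 4 runs the other way, returning an aromatic ring to where the carboxy group sat, although that ring now carries chlorine rather than methoxy, so the step is expected to be large and downward, coming close to undoing that earlier loss. On that basis compound 4 is expected to give 800 nM, with a likely range from 300 nM to 2500 nM, which would mean a step of a 19-fold lower number from compound 3 to compound 4 (1.27 log units; beyond the scatter).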

Compound 4, half-maximal inhibitory concentration: 540 nM
For compound 4 the middle estimate is 1.5-fold (0.17 log units) above the measured one, and the stated range covers the measured number.
By their numbers in this assay, from the lowest: compounds 4 and 1 (each within the scatter of the next); then compound 2; then compound 3.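

In this assay, the step back from carboxy to an aromatic ring brings a large fall in the number (a 28-fold lower number from compound 3 to compound 4 (1.44 log units; beyond the scatter)), so the loss seen earlier with carboxy (a 24-fold higher number from compound 1 to compound 3 (1.38 log units; beyond the scatter)) is not tied to 4-methoxyphenyl alone: a second, different ring on the same saturated chain carbon recovers it. Exchanging one ring for the other leaves the number within the usual scatter (a 1.2-fold lower number from compound 1 to compound 4 (0.07 log units; within the scatter)), so 3-chlorophenyl and 4-methoxyphenyl cannot be told apart at this position. No measurement shown here explains why either ring-bearing compound differs from the carboxy compound.

Still open, from the compounds shown here alone, is whether a plain phenyl ring, with neither chlorine nor methoxy, would fit the same picture. Equally open, going by these compounds, is how an amine in place of carboxy, or a longer chain carrying the ring, would behave.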